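The source may report more compounds than this note shows. Statements on the series, on what has been measured and on what is new or still open speak of the compounds shown alone.

Measured compounds in a functional assay on KYSE-450 cells (Homo sapiens) for inhibition, read by MTT assay, with a stated time of 48 h; on this read-out higher numbers stand for weaker inhibition and lower numbers for stronger inhibition:
compound 1 `C/C=C/C(=O)N(Cc1ccc(OC)c(C)c1)c1cc(OC)c(OC)c(OC)c1` gives 32900 nM
compound 2 `COc1ccc(CN(C(=O)C[Se]C#N)c2cc(OC)c(OC)c(OC)c2)cc1O` gives 280 nM
compound 3 `COc1ccc(CNc2cc(OC)c(OC)c(OC)c2)cc1[N+](=O)[O-]` gives 16800 nM

Among the three measured compounds, compound 2 stands with the lowest number in this assay, and its distance to both compound 3 and compound 1 lies beyond the scatter, so compound 2 is the most potent of the three on this read-out. Compound 4 `COc1ccc(CN(C(=O)CO)c2cc(OC)c(OC)c(OC)c2)cc1O` has not yet been measured in this assay. It differs from compound 2 in one place: one oxygen atom in place of a group of 3 heavy atoms (1 carbon, 1 nitrogen, 1 selenium; no ring), on a saturated chain carbon bound to a carbonyl carbon. Going by the values given here, the selenium-bearing group is the only feature that sets compound 2 apart from the two weaker compounds, and compound 4 gives that group up for a hydroxy. Compound 4 is therefore expected to move a long way toward the values of compound 1 and compound 3, and the step from compound 2 to compound 4 is estimated as a 43-fold higher number from compound 2 to compound 4 (1.63 log units; beyond the scatter), a loss well beyond the scatter. On that basis compound 4 is expected to give about 12000 nM in this assay, with a likely range from 2500 nM to 45000 nM.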

Compound 4, half-maximal inhibitory concentration: 370 nM
Compound 4: middle estimate off by 32-fold (1.51 log units), on the high side, and the stated range ends above it.
By their numbers in this assay, from the lowest: compounds 2 and 4 (each within the scatter of the next); then compounds 3 and 1 (each within the scatter of the next).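

In this assay, the group of 3 heavy atoms carrying selenium gives way to hydroxy, on a saturated chain carbon bound to a carbonyl carbon, with the result staying within the scatter (a 1.3-fold higher number from compound 2 to compound 4 (0.12 log units; within the scatter)). At this position, then, neither selenium nor a triple bond is needed for a value in this range, since compound 4 carries neither and gives 370 nM. No measurement shown here accounts for the two groups reading alike.

On these data alone, whether an amine, a carboxylic acid or a longer chain on this same carbon would also stay within the scatter of compound 4 remains open. So does the reading of a thiocyanate, with sulfur in the place of selenium, on this carbon.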